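Swapping the aryl group on a triazole nitrogen

This account rests on a few compounds, and the source may have more. Where it says the series, first, only, none or still open, it means among the compounds named here.

Compounds measured in a functional assay on MCF7 cells (Homo sapiens) for antiproliferative activity, read by MTT assay, with a stated time of 48 h; a higher number here means a weaker inhibitor, a lower number a stronger inhibitor:
Compound 1 `Cc1cccc(-n2nncc2CN2C(=O)C3(C(C#N)=C(N)Oc4c3c3nc5ccccc5nc3c3ccccc43)c3ccccc32)c1` gives > 50000 nM, a limit of the assay.
Compound 2 `N#CC1=C(N)Oc2c(c3nc4ccccc4nc3c3ccccc23)C12C(=O)N(Cc1cnnn1-c1ccccc1Cl)c1ccccc12` gives > 50000 nM, also a limit.
Compound 3 `N#CC1=C(N)Oc2c(c3nc4ccccc4nc3c3ccccc23)C12C(=O)N(Cc1cnnn1-c1ccc(N)cc1)c1ccccc12` gives > 50000 nM, again a limit.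

Compound 2 stands nowhere readable on these numbers: its value is a limit, and the two other values are limits as well, so none of the three can be placed against the others. The piece follows the change from compound 2 to compound 4 `Cc1ccc(C)c(-n2nncc2CN2C(=O)C3(C(C#N)=C(N)Oc4c3c3nc5ccccc5nc3c3ccccc43)c3ccccc32)c1`, in which (2,5-dimethylphenyl in place of 2-chlorophenyl on an aromatic nitrogen). Going by the values given here, the steps that bear on it all change the same aryl group on the aromatic nitrogen: a step that the two limits leave unreadable from compound 1 to compound 2, a step that the two limits leave unreadable from compound 1 to compound 3 and a step that the two limits leave unreadable from compound 2 to compound 3. Each is hidden because of the limit of > 50000 nM in this assay, at which 3 of the 3 values shown sit. Three different aryl groups in this place have given only limits, so the expectation for a fourth is the same: the step that the limit leaves unreadable from compound 2 to compound 4 is expected to be unreadable, with no direction beyond the scatter to claim. Compound 4 is therefore expected to give about 60000 nM, within 25000 nM to 150000 nM, most likely again as a limit rather than a number.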

Compound 4, half-maximal inhibitory concentration: > 50000 nM
Compound 4: no number, only a limit (the forecaster's own chance of this, stated with the estimate: 85%); the middle value does not contradict the limit.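

Going by these compounds alone, compound 4 is also only a limit, so no step between it and compound 1, compound 2 or compound 3 can be read: the limit of > 50000 nM in this assay, at which 4 of the 4 values shown sit.

From the compounds shown here alone, whether any aryl group in this place gives a readable number in this assay remains open across these four compounds.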